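The source may hold more compounds than are shown below. What is called first, only, known or untested is meant among the compounds shown, and "the series" means these compounds.

Among the compounds with values here, compound 2 `CCCCCCc1c(F)c(N)c2c(=O)cc(-c3ccc(N)c(F)c3)oc2c1F` is the one member of this small set that gives a true number: in a functional assay on HeLa cells (Homo sapiens) for cytotoxicity, read by neutral red uptake, with a stated time of 3 days (on this read-out higher numbers stand for weaker inhibition and lower numbers for stronger inhibition), compound 2 reaches 21000 nM. Compound 1 `Nc1ccc(-c2cc(=O)c3c(N)c(F)cc(F)c3o2)cc1F` gives only a limit of the assay, > 100000 nM. Compound 3 `Nc1ccc(-c2cc(=O)c3c(N)c(F)c(Cl)c(F)c3o2)cc1F` likewise gives only a limit, > 100000 nM. The shared core thus sits at the limit of > 100000 nM in this assay, at which 2 of the 3 values shown sit, for two of the three compounds, and compound 2 alone falls below it. Hexyl in place of hydrogen on an aromatic carbon gives an at least 4.7-fold lower number from compound 1 to compound 2 (0.67 log units; beyond the scatter), while chloro in place of hexyl on an aromatic carbon gives an at least 4.7-fold higher number from compound 2 to compound 3 (0.67 log units; beyond the scatter); between the two limits there is a step that the two limits leave unreadable from compound 1 to compound 3.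

Compound 4 `COCc1c(F)c(N)c2c(=O)cc(-c3ccc(N)c(F)c3)oc2c1F` is not yet measured. Its difference from compound 2 is methoxy in place of pentyl on a saturated chain carbon bound to an aromatic carbon. Pentyl leaves and methoxy enters, so most of the hexyl chain that distinguished compound 2 from compound 1 is gone. Within the data shown here, the step that bears most on this change is the one from compound 1 to compound 2, which went the other way and was at least modest, and the chloro step on the same carbon also pushed the number back up to the limit. In this assay the step is therefore expected to read a 3.8-fold higher number from compound 2 to compound 4 (0.58 log units; beyond the scatter). Compound 4 is expected to give about 80000 nM, within 25000 nM to 300000 nM.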

Compound 4, half-maximal inhibitory concentration: > 100000 nM
Compound 4 gave a limit, no number; the forecaster's own chance of this, stated with the estimate: 50%; middle value at least 1.2-fold (0.09 log units) from the limit.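

Methoxy in place of pentyl on a saturated chain carbon bound to an aromatic carbon gives an at least 4.7-fold higher number from compound 2 to compound 4 (0.67 log units; beyond the scatter), so in this assay the lower number that came with hexyl does not carry over to methoxymethyl. Before this result, the only substituent shown to return this place to the limit was chloro in compound 3, which has no chain at all; compound 4 shows that a chain-bearing group can do the same, so a short chain there is not enough to give a true number, and among the compounds shown only compound 2 with its hexyl gives one. Compound 4 gives a limit of the assay and not a number, like compound 1 and compound 3: the limit of > 100000 nM in this assay, at which 3 of the 4 values shown sit.

The steps from compound 1 and from compound 3 to compound 4 run from limit to limit and cannot be read, so nothing can be said about how methoxymethyl compares with hydrogen or chloro. Because pentyl left and methoxy entered in one change, the compounds shown do not separate chain length from the oxygen, and a plain propyl or butyl chain, a longer chain such as octyl, or a hexyl chain ending in an amine would each remain to be seen in this series.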